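Swapping a Quinoline for Chlorophenyl in a Polyamide Series

This account rests on a few compounds, and the source may have more. Where it says the series, first, only, none or still open, it means among the compounds named here.

Four compounds share a chain of linked aromatic amide units that ends in a basic side chain. Compound 1 `COc1cccc(C(=N)Nc2cc(C(=O)Nc3cc(C(=O)Nc4cc(C(=O)NCCCN(C)C)n(C)c4)n(C)c3)n(C)c2)c1` and compound 3 `CN(C)CCCNC(=O)c1cc(NC(=O)c2cc(NC(=O)c3cc(NC(=N)c4ccccc4)cn3C)cn2C)cn1C` have no number in an ADME assay on HEK293 cells (Homo sapiens) for cytotoxicity, read by fluorescence and resazurin assay, with a stated time of 20 h; a lower number here means that less compound is tolerated, a higher number that more compound is tolerated; for compound 1 the record shows "not determined" (no result reported) and for compound 3 it shows "not determined" (no result reported). Among the compounds with values here, that leaves compound 2 `CC(C)CCc1sc(NC(=O)c2cc(NC(=O)c3cc(NC(=N)c4cnc5ccccc5c4)cn3C)cn2C)nc1C(=O)NCCCN(C)C` as the only member with a measured value: in this assay compound 2 gives 1.2 ug/mL, so it stands alone and cannot be ranked against the others.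

Compound 4 `CC(C)CCc1sc(NC(=O)c2cc(NC(=O)c3cc(NC(=N)c4ccc(Cl)cc4)cn3C)cn2C)nc1C(=O)NCCCN(C)C` differs from compound 2 at one end of the chain: 4-chlorophenyl in place of quinolin-3-yl on a carbon with a double bond to nitrogen. Within the data shown here, no measured pair in this set shows what such a change does, so there is nothing to lean on beyond the single value of compound 2. The expected step from compound 2 to compound 4 in this assay is therefore no change at the digits printed from compound 2 to compound 4 (within the scatter), that is, no change beyond the scatter of repeated measurements. Compound 4 is expected to give 1.2 ug/mL, with a range from 0.5 ug/mL to 3 ug/mL.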

Compound 4, half-maximal cytotoxic concentration: 10 ug/mL
The estimate for compound 4 lay 8.3-fold (0.92 log units) below the measured number; measured number above the stated range.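

In this assay, the group on a carbon with a double bond to nitrogen proves able to shift the result on its own: 4-chlorophenyl in place of quinolin-3-yl gives an 8.3-fold higher number from compound 2 to compound 4 (0.92 log units; beyond the scatter), while the rest of the chain stays the same. Within the data shown here, this is the first measured pair in the set, so it marks this end of the chain as a place where tolerance by the cells can change. No measurement shown here bears on the reason for this step.

A single pair cannot separate the effect of gaining the chlorine from that of losing the second ring of quinolin-3-yl. A 4-fluorophenyl or a naphthalen-2-yl at the same place, on the otherwise unchanged chain of compound 2, would help to tell these two apart.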